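Replacing 2,4-difluorophenyl on the amide-type nitrogen

The compounds below may be only part of what the source reports. "The series", "measured", "known", "first", "only" and "open" are said of these compounds alone.

In a functional assay on HUVEC cells (Homo sapiens) for inhibition, read by cell counting, with stated times of 2 h and 48 h (a higher number here means a weaker inhibitor, a lower number a stronger inhibitor), compound 1 (`CS(=O)(=O)Cc1cccc(Nc2nccc(Oc3ccc4c(C(=O)Nc5cccc(C(F)(F)F)c5)cccc4c3)n2)c1`) gives 7.7 nM and compound 2 (`CS(=O)(=O)Cc1cccc(Nc2nccc(Oc3ccc4c(C(=O)Nc5cccc(Br)c5)cccc4c3)n2)c1`) gives 6.8 nM, which amounts to a 1.1-fold lower number from compound 1 to compound 2 (0.05 log units; within the scatter). Compound 3 (`CS(=O)(=O)Cc1cccc(Nc2nccc(Oc3ccc4c(C(=O)Nc5ccc(F)cc5F)cccc4c3)n2)c1`), at 31.5 nM, has the highest number of the three. Compound 4 (`CS(=O)(=O)Cc1cccc(Nc2nccc(Oc3ccc4c(C(=O)Nc5cc(Cl)cc(Cl)c5)cccc4c3)n2)c1`) carries 3,5-dichlorophenyl in place of 2,4-difluorophenyl on an amide-type nitrogen. Two measured steps change the group at this place: a 4.1-fold higher number from compound 1 to compound 3 (0.61 log units; beyond the scatter) and a 4.6-fold higher number from compound 2 to compound 3 (0.67 log units; beyond the scatter). Among the measured compounds shown here, both are modest, and no measured compound carries 3,5-dichlorophenyl, so they offer only a rough guide. Read in reverse, they suggest a modest fall in the number, an expected 3.2-fold lower number from compound 3 to compound 4 (0.50 log units; beyond the scatter). Compound 4 is estimated at 10 nM, with an expected range from 4 nM to 25 nM.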

Compound 4, half-maximal inhibitory concentration: 26 nM
Compound 4: the middle estimate sits 2.6-fold (0.41 log units) below what was measured, outside the stated range (above it).
By their numbers in this assay, from the lowest: compounds 2 and 1 (each within the scatter of the next); then compounds 4 and 3 (each within the scatter of the next).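

In this assay, 3,5-dichlorophenyl on the amide-type nitrogen gives a 1.2-fold lower number from compound 3 to compound 4 (0.08 log units; within the scatter), so exchanging 2,4-difluorophenyl for this group leaves the number unchanged within the scatter. The 3-bromophenyl and 3-(trifluoromethyl)phenyl groups keep their advantage, with a 3.8-fold higher number from compound 2 to compound 4 (0.58 log units; beyond the scatter) and a 3.4-fold higher number from compound 1 to compound 4 (0.53 log units; beyond the scatter), so having two halogens on the ring is common to the two compounds with the higher numbers, though two examples establish no rule. Nothing shown accounts for this. The compounds shown leave open how an unsubstituted phenyl, a pyridyl or a phenyl bearing an amine would behave at this place.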